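The source may hold more compounds than are shown below. What is called first, only, known or untested is meant among the compounds shown, and "the series" means these compounds.

Compound 1 `O=C(O)CCCSCCN1C(=O)CC[C@@H]1/C=C/[C@@H](O)Cc1cccc(-c2nc3ccccc3s2)c1` gives > 10000 nM in an assay on CHO cells for displacement of a labelled ligand from prostaglandin E2 receptor EP3 subtype (Mus musculus), read by scintillation counting, with a stated time of 60 min (a lower number here means a stronger inhibitor, a higher number a weaker inhibitor), which is a limit of the assay and not a number.
Compound 2 `O=C(O)CCCSCCN1C(=O)CC[C@@H]1/C=C/[C@@H](O)Cc1cccc(OCc2ccncc2)c1` gives > 10000 nM in this assay, again a limit.
Compound 3 `O=C(O)c1csc(SCCN2C(=O)CC[C@@H]2/C=C/[C@@H](O)Cc2cccc(-c3ccccc3)c2)n1` gives 4300 nM in this assay.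

Within the data shown here, compound 3 thus carries the only number among the three values shown; the other two sit at the limit, as described by the limit of > 10000 nM in this assay, at which 2 of the 3 values shown sit. Among the measured compounds shown here, the one step between measured compounds, a step that the two limits leave unreadable from compound 1 to compound 2, runs from one limit to another and its size cannot be read.

Compound 4 `O=C(O)c1csc(SCCN2C(=O)CC[C@@H]2/C=C/[C@@H](O)Cc2cccc(-c3nc4ccccc4o3)c2)n1` differs from compound 3 in one place: 1,3-benzoxazol-2-yl in place of phenyl on an aromatic carbon. For the measured compounds named here, no measured step covers this change directly. The nearest comparison is compound 1, where a 1,3-benzothiazol-2-yl stands on the same aromatic carbon, though on a different acid chain; compound 1 sits at the limit while compound 3 gives a number. Taken together, these values point to a weakening step in this assay, but how large it is cannot be read from a limit.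

The expected step from compound 3 to compound 4 is therefore a 2.1-fold higher number from compound 3 to compound 4 (0.32 log units; beyond the scatter), toward weaker inhibition. For compound 4 the estimate in this assay is 9000 nM, with a range from 2500 nM to 30000 nM, and a real chance that only a limit is reported.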

Compound 4, inhibition constant: > 10000 nM
Compound 4: a limit, no number; the forecaster's own chance of this, stated with the estimate: 40%; middle value at least 1.1-fold (0.04 log units) from the limit.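

In this assay, putting 1,3-benzoxazol-2-yl in place of phenyl on this aromatic carbon, with the rest of the structure unchanged, gives an at least 2.3-fold higher number from compound 3 to compound 4 (0.36 log units; beyond the scatter). Among these compounds, this is the first step that can be read, though only as a lower bound on its size, while the step between the two earlier limits cannot be read. Compound 4 gives a limit and not a number, and it now stands with compounds 1 and 2 at that limit: the limit of > 10000 nM in this assay, at which 3 of the 4 values shown sit.

Among the compounds shown here, how far compound 4 lies past the limit stays unknown, so the full size of the step remains open, and with only one number, nothing here shows which feature of the incoming group matters: its second ring, its hetero atoms or its greater size. As far as these compounds go, it also remains open whether a methoxy group or an amine on this aromatic carbon, or 1,3-benzothiazol-2-yl carried on the acid chain of compound 3, would give a number in this assay rather than a limit.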